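Methylating the indole nitrogen of compound 1

The source may hold more compounds than are shown below. What is called first, only, known or untested is meant among the compounds shown, and "the series" means these compounds.

Compound 1 `COc1cc(C(=O)/C(C)=C/c2c[nH]c3ccccc23)cc([Se]C)c1OC` gives 12 nM.
Compound 2 `COc1ccc2c(/C=C/C(=O)c3cc(N)c(OC)c(OC)c3)c[nH]c2c1` gives 193 nM.
Compound 3 `COc1ccc2c(/C=C(\C)C(=O)c3cc(OC)c(OC)c([Se]C)c3)c[nH]c2c1` gives 8 nM.

In a functional assay on A549 cells (Homo sapiens) for antiproliferative activity, read by MTT assay, with a stated time of 48 h (a lower number here means a stronger inhibitor, a higher number a weaker inhibitor), compound 1 sits second highest of the three numbers. Its nearest neighbour is compound 3, the step of a 1.5-fold lower number from compound 1 to compound 3 (0.18 log units; within the scatter), a change on an aromatic carbon that stays inside the scatter. Compound 2 lies furthest away, and the values of compound 1 and compound 2 in this assay show the larger gap.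

Compound 4 `COc1cc(C(=O)/C(C)=C/c2cn(C)c3ccccc23)cc([Se]C)c1OC` differs from compound 1 in one place: methyl in place of hydrogen on an aromatic nitrogen. Among the measured compounds shown here, none of the measured steps touches the aromatic nitrogen; the only single-point step, a 1.5-fold lower number from compound 1 to compound 3 (0.18 log units; within the scatter), concerns an aromatic carbon and is within the scatter, so it offers no guide in either direction. The expectation for compound 4 is therefore no step beyond the scatter, with the estimated change a 1.3-fold higher number from compound 1 to compound 4 (0.10 log units; within the scatter). Compound 4 is estimated at 15 nM in this assay, in a range from 5 nM to 45 nM.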

Compound 4, half-maximal inhibitory concentration: 18 nM
Compound 4: the middle estimate sits 1.2-fold (0.08 log units) below what was measured; measured number inside the range.
By their numbers in this assay, from the lowest: compounds 3, 1 and 4 (each within the scatter of the next, the first and the last beyond it); then compound 2.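

In this assay, among the compounds shown here, the first measured change at this aromatic nitrogen gives a 1.5-fold higher number from compound 1 to compound 4 (0.18 log units; within the scatter), so methyl can take the place of hydrogen on the nitrogen of the five-membered aromatic ring without a step beyond the scatter. In this pair, then, the hydrogen on that nitrogen is not required for a number of this order, and a methyl with no hydrogen-bond donor serves as well within the scatter. Nothing in the data at hand explains this outcome.

On these data alone, whether a longer chain such as ethyl or propyl, a benzyl group or an acetyl group on the same nitrogen would stay within the scatter remains open. As far as these compounds go, it is also open whether the methyl would give a similar step in the core of compound 3, which carries an added methoxy group.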